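Swapping methyl for chloro on the outer phenoxy ring

A few compounds are considered here, and "the series" means these few. Any claim that something is new, unique, unknown or untested is made for them only; others in the source may bear on it.

Three quinazolinone-type compounds share one core, and their lipophilicity was measured in a physicochemical assay for lipophilicity, in phosphate buffer, measured as octanol-water partition; on this read-out higher numbers stand for higher lipophilicity and lower numbers for lower lipophilicity. Compound 1 `O=c1c2ccccc2nc(-c2ccccc2)n1/N=C/c1ccc(Oc2ccccc2)cc1` gives 6.13. Compound 2 `Cc1ccc(Oc2ccc(/C=N/n3c(-c4ccccc4)nc4ccccc4c3=O)cc2)cc1` gives 6.29, and the two sit within the scatter of each other, as a number 0.16 log units higher from compound 1 to compound 2 (within the scatter) shows. Compound 3 `CCCc1nc2ccccc2c(=O)n1/N=C/c1ccc(Oc2ccc(C)cc2)cc1` gives 5.45; the step of a number 0.84 log units lower from compound 2 to compound 3 (beyond the scatter) is beyond the scatter and is the only clear separation among the three.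

Compound 4 `O=c1c2ccccc2nc(-c2ccccc2)n1/N=C/c1ccc(Oc2ccc(Cl)cc2)cc1` has not yet been measured. It differs from compound 2 by chloro in place of methyl on an aromatic carbon, sitting on an aromatic carbon of a six-membered aromatic ring of carbon only, para to a large group. Among the compounds with values here, of the measured steps, only the one placing methyl at that same position, a number 0.16 log units higher from compound 1 to compound 2 (within the scatter), touches this spot, and it was within the scatter. Within the data shown here, no measured step tells what chloro does here. The expectation is therefore a step of a number 0.11 log units higher from compound 2 to compound 4 (within the scatter) that stays within the scatter, and compound 4 is estimated at 6.4, with a range from 6.05 to 6.75.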

Compound 4, partition coefficient: 6.38
Beside the measured number, compound 4's estimate is 0.02 log units above it; the range from low to high includes it.
By their numbers in this assay, from the lowest: compound 3; then compounds 1, 2 and 4 (each within the scatter of the next).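

In this assay, swapping methyl for chloro at this spot, on an aromatic carbon para to a large group, gives a number 0.09 log units higher from compound 2 to compound 4 (within the scatter) and so stays inside the usual scatter. Chloro in place of hydrogen at the same carbon gives a number 0.25 log units higher from compound 1 to compound 4 (within the scatter) and also stays inside it, which puts hydrogen, methyl and chloro here, in compounds 1, 2 and 4, all within the scatter of one another. No measurement at hand offers an explanation for this closeness.

The compounds shown leave open whether a group of another kind on this carbon, such as an amine or a carboxylic acid, would shift the number beyond the scatter. They also leave open whether chloro would read the same with the propyl of compound 3 on the core instead of phenyl.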